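The compounds below may be only part of what the source reports. "The series", "measured", "known", "first", "only" and "open" are said of these compounds alone.

Measured so far in an ADME assay on Caco-2 cells (Homo sapiens) for permeability, in the apical to basolateral direction; on this read-out lower numbers stand for lower permeability and higher numbers for higher permeability:

compound 1 `Cn1cncc1CN1CC(N(CC2CCN(C(=O)CC(C)(C)C)CC2)S(=O)(=O)c2ccccn2)Cc2cc(C#N)ccc21`: 0.5 10^-6 cm/s
compound 2 `Cn1cncc1CN1CC(N(CC2CCN(C(=O)NC(C)(C)C)CC2)S(=O)(=O)c2ccccn2)Cc2cc(C#N)ccc21`: 0.6 10^-6 cm/s
compound 3 `Cn1cncc1CN1CC(N(CC2CCN(C(=O)c3ccco3)CC2)S(=O)(=O)c2ccccn2)Cc2cc(C#N)ccc21`: 0.5 10^-6 cm/s

All three numbers sit close together. Compound 3 stands level with compound 1, no change at the digits printed from compound 1 to compound 3 (within the scatter), and the remaining gap is likewise small, a 1.2-fold lower number from compound 2 to compound 3 (0.08 log units; within the scatter), so nothing in the set separates one compound from another beyond the scatter. The three measured steps all exchange the group on a carbonyl carbon that hangs from the ring amine nitrogen, and none of them moves the read-out: a 1.2-fold higher number from compound 1 to compound 2 (0.08 log units; within the scatter), no change at the digits printed from compound 1 to compound 3 (within the scatter), a 1.2-fold lower number from compound 2 to compound 3 (0.08 log units; within the scatter).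

Compound 4 `Cn1cncc1CN1CC(N(CC2CCN(S(=O)(=O)c3ccccc3)CC2)S(=O)(=O)c2ccccn2)Cc2cc(C#N)ccc21` carries the next change at the same ring amine nitrogen: phenylsulfonyl in place of (furan-2-yl)carbonyl on an amine nitrogen in a ring. Among the compounds with values here, this goes further than the earlier exchanges, since the carbonyl itself is replaced by a sulfonyl, and no measured pair covers that kind of swap. Within the data shown here, what bears on it is only that three different groups at this position left the number unchanged within the scatter, with the rest of the structure constant.

The expectation is therefore a step of no change at the digits printed from compound 3 to compound 4 (within the scatter), that is, none beyond the scatter. Compound 4 is estimated at 0.5 10^-6 cm/s, with a range of 0.25 10^-6 cm/s to 1 10^-6 cm/s.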

Compound 4, apparent permeability: 0.1 10^-6 cm/s
The estimate for compound 4 lay 5.0-fold (0.70 log units) above the measured number, outside the stated range (below it).
By their numbers in this assay, from the lowest: compound 4; then compounds 1, 3 and 2 (each within the scatter of the next).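

In this assay the amine nitrogen in the six-membered ring is not indifferent to every exchange: phenylsulfonyl brings a 5.0-fold lower number from compound 3 to compound 4 (0.70 log units; beyond the scatter) and also a 6.0-fold lower number from compound 2 to compound 4 (0.78 log units; beyond the scatter) and a 5.0-fold lower number from compound 1 to compound 4 (0.70 log units; beyond the scatter) and so sets compound 4 apart from all three carbonyl-bearing compounds. Those three compounds lie within the scatter of each other, so the size of the step hardly depends on whether neopentyl, (tert-butyl)amino or furan-2-yl stood on the carbonyl that leaves. The series therefore gains its first change at this position that moves the read-out beyond the scatter, but nothing at hand gives a measured reason for the step.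

This change replaces the carbonyl with a sulfonyl and the five-membered aromatic ring with a phenyl in a single step, so the compounds shown do not tell which of the two carries the step. Benzoyl on the same nitrogen would keep the carbonyl with the phenyl, while (furan-2-yl)sulfonyl or methylsulfonyl would keep the sulfonyl with a different group, and these would separate the two parts of the change.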